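Trading Five Heavy Atoms for an Amino Group

The compounds below may be only part of what the source reports. "The series", "measured", "known", "first", "only" and "open" are said of these compounds alone.

Compound 1 `Nc1cc(-c2ccc(Cl)cc2)nn1-c1cccc(Cl)c1`, compound 2 `Cc1ccc(-c2nn(-c3cccc(Cl)c3)c(/N=C/N(C)C)c2C=O)cc1` and compound 3 `CN(C)/C=N/c1cc(-c2ccc(Cl)cc2)nn1-c1cccc(Cl)c1` were tested in a functional assay on NPC-TW01 cells (Homo sapiens) for inhibition, read by MTT assay, with a stated time of 72 h; a higher number here means a weaker inhibitor of growth, a lower number a stronger inhibitor of growth. In this assay compound 2 gives 7200 nM and compound 3 gives 92700 nM, so compound 2 gives the lower of the two numbers. For compound 1 this assay reports only a limit, > 100000 nM, and not a number. How the core of compound 2 differs from the core of compound 3 is not broken down here.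

Compound 3 and compound 1 differ in one place: one nitrogen atom in place of a group of 5 heavy atoms (3 carbon, 2 nitrogen; no ring), on an aromatic carbon. The step is an at least 1.0-fold higher number from compound 3 to compound 1 (0.03 log units; that floor lies within the scatter), and it is only a floor because of the limit of > 100000 nM in this assay, at which 1 of the 3 values shown sits.

Compound 4 `Cc1ccc(-c2nn(-c3cccc(Cl)c3)c(N)c2C=O)cc1`, not yet measured, arises from compound 2 by the same kind of change: one nitrogen atom in place of a group of 5 heavy atoms (3 carbon, 2 nitrogen; no ring), on an aromatic carbon. The surroundings are not identical. In compound 4 the altered carbon sits next to the ring atom that bears a formyl group, and two ring bonds from the ring atom that bears a 4-methylphenyl group, whereas in compound 1 that position bears a 4-chlorophenyl group and no formyl group is present.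

Beside the measured step from compound 3 to compound 1, the step from compound 2 to compound 4 is expected to be a 1.7-fold higher number from compound 2 to compound 4 (0.22 log units; within the scatter) in this assay, resting on compound 3 and compound 1 showing an at least 1.0-fold higher number from compound 3 to compound 1 (0.03 log units; that floor lies within the scatter). Compound 4 is therefore estimated at 12000 nM in this assay, expected to fall between 4000 nM and 50000 nM.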

Compound 4, concentration for 50% growth inhibition: > 100000 nM
Compound 4 ended at the assay's limit; the forecaster's own chance of this, stated with the estimate: 10%; at least 8.3-fold (0.92 log units) between middle value and limit.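

On the core of compound 2 in this assay, replacing the five-atom group with amino gives a large change: an at least 13-fold higher number from compound 2 to compound 4 (1.14 log units; beyond the scatter). Set beside the same change on the core of compound 3, this result does not establish whether the change carries over from one core to the other with the same size: the same change on two cores in this assay, an at least 1.0-fold higher number (0.03 log units; that floor lies within the scatter) from compound 3 to compound 1 and an at least 13-fold higher number (1.14 log units; beyond the scatter) from compound 2 to compound 4; the limit leaves it open whether they differ. Among the compounds shown here, the readings for both amino compounds, compound 1 and compound 4, end at a limit and not at a number, so the true size of neither step is known, and the pair shows only that neither amino compound gave a number within the range of the assay: the limit of > 100000 nM in this assay, at which 2 of the 4 values shown sit.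

The compounds shown leave open how other groups would read on this aromatic carbon, such as a methylamino group or an acetamide, which could show whether any group smaller than the five-atom one keeps a measurable value. They also leave open what the formyl group contributes on its own, a question that a nitrile or a carboxylic acid at that ring atom, on an otherwise unchanged core of compound 2, could address.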